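The compounds below may be only part of what the source reports. "The series", "measured", "known", "first", "only" and "open" are said of these compounds alone.

Measured compounds in a functional assay on K562 cells (Homo sapiens) for cytotoxicity, read by sulforhodamine B assay; on this read-out lower numbers stand for stronger inhibition and higher numbers for weaker inhibition:
Compound 1 `[N-]=[N+]=N[C@@H]1C(n2ccc(=O)[nH]c2=O)[Se][C@H](CO)[C@H]1O`. In this assay compound 1 gives > 100000 nM, a limit of the assay.
Compound 2 `[N-]=[N+]=N[C@@H]1C(n2cc(F)c(=O)[nH]c2=O)[Se][C@H](CO)[C@H]1O`. In this assay compound 2 gives > 100000 nM, a limit of the assay.
Compound 3 `[N-]=[N+]=N[C@@H]1C(n2cc(Cl)c(=O)[nH]c2=O)[Se][C@H](CO)[C@H]1O`. In this assay compound 3 gives > 100000 nM, a limit of the assay.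

Compound 2 therefore stands at a limit only, and the two other values shown sit at the same limit (the limit of > 100000 nM in this assay, at which 3 of the 3 values shown sit). Compound 4 `[N-]=[N+]=N[C@@H]1C(n2cc(Br)c(=O)[nH]c2=O)[Se][C@H](CO)[C@H]1O` differs from compound 2 by bromo in place of fluoro on an aromatic carbon. The measured steps that bear on this exchange are all unreadable: a step that the two limits leave unreadable from compound 1 to compound 2, a step that the two limits leave unreadable from compound 1 to compound 3 and a step that the two limits leave unreadable from compound 2 to compound 3. The closest comparison, a heavier halogen in place of fluoro at the same place, did not bring compound 3 inside the measurable range. On that basis the step of a number no higher from compound 2 to compound 4 (the limit leaves the size open) is expected to stay within the scatter, with no number beyond the limit. Compound 4 is estimated at 100000 nM, with a range from 30000 nM to 300000 nM, and most likely reported as a limit again.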

Compound 4, half-maximal inhibitory concentration: > 100000 nM
Compound 4: no number, only a limit; the forecaster's own chance of this, stated with the estimate: 85%; the middle value lies on the limit itself.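

No step between compound 4 and compound 1, compound 2 or compound 3 can be read in this assay, as every value is a limit of the assay: the limit of > 100000 nM in this assay, at which 4 of the 4 values shown sit.

The compounds shown leave open whether hydrogen, fluoro, chloro and bromo on this aromatic carbon differ at all in this assay.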